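The source may hold more compounds than are shown below. What is called first, only, known or untested is meant among the compounds shown, and "the series" means these compounds.

Measured in a functional assay on HT-29 cells (Homo sapiens) for cytotoxicity, read by MTT assay, with a stated time of 72 h; a lower number here means a stronger inhibitor, a higher number a weaker inhibitor:
compound 1 `Cn1c(=O)c(C(=O)Nc2ccc(Oc3ccncc3-c3cccnc3)c(F)c2)nn(-c2ccc(Cl)cc2)c1=O`, 440 nM
compound 2 `Cn1c(=O)c(C(=O)Nc2ccc(Oc3ccncc3-c3cccnc3)c(F)c2)nn(-c2c(Cl)cccc2Cl)c1=O`, 780 nM

Compound 2 stands with compound 1 at one level on the two numbers available: the step of a 1.8-fold higher number from compound 1 to compound 2 (0.25 log units; within the scatter) lies within the scatter, so the two cannot be told apart in this assay. Both share the same core and differ only in the aryl group on the aromatic nitrogen.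

Compound 3 `COc1ccc(-n2nc(C(=O)Nc3ccc(Oc4ccncc4-c4cccnc4)c(F)c3)c(=O)n(C)c2=O)c(OC)c1` carries 2,4-dimethoxyphenyl in place of 2,6-dichlorophenyl on an aromatic nitrogen. Within the data shown here, the one measured step, a 1.8-fold higher number from compound 1 to compound 2 (0.25 log units; within the scatter), varies the same aryl group and stays within the scatter; no measured step involves a methoxy group, so the size of any effect from the 2,4-dimethoxyphenyl is unknown. Given the flat response seen so far, the expected step is a 1.1-fold lower number from compound 2 to compound 3 (0.05 log units; within the scatter), none beyond the scatter. In this assay compound 3 is estimated at 700 nM, with a range from 250 nM to 2000 nM.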

Compound 3, half-maximal inhibitory concentration: 890 nM
For compound 3 the middle estimate is 1.3-fold (0.10 log units) below the measured one; the measured number falls inside the stated range.
By their numbers in this assay, from the lowest: compounds 1, 2 and 3 (each within the scatter of the next, the first and the last beyond it).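

On the aromatic nitrogen, 2,4-dimethoxyphenyl in place of 2,6-dichlorophenyl gives a 1.1-fold higher number from compound 2 to compound 3 (0.06 log units; within the scatter), so in this assay a group with two hydrogen-bond acceptors and no chlorine cannot be told apart from the dichlorinated one. Against 4-chlorophenyl, the same group gives a 2.0-fold higher number from compound 1 to compound 3 (0.31 log units; beyond the scatter), the only step at this position beyond the scatter and a modest one, while compound 2 lies within the scatter of both neighbours. Nothing available bears on what lies behind these steps.

On these data alone, all three groups on this nitrogen are phenyl rings carrying chlorine or methoxy, so the effect of an amine or a carboxylic acid there remains open. As far as these compounds go, the methyl group and the fluorine are the same in all three compounds, so what a change at either would do in this assay also remains open.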